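Two measured compounds and a methylamino analogue

The source may report more compounds than this note shows. Statements on the series, on what has been measured and on what is new or still open speak of the compounds shown alone.

Compound 1 `O=C(Nc1ccc(-n2ncc3c(Br)cccc32)cc1)Nc1ccc(Cl)c(C(F)(F)F)c1` and compound 2 `Cc1cccc2c1cnn2-c1ccc(NC(=O)Nc2ccc(Cl)c(C(F)(F)F)c2)cc1` share one core and differ at a single aromatic carbon of the fused system. In a functional assay on LoVo cells (Homo sapiens) for cytotoxicity, read by MTT assay, with a stated time of 72 h (a lower number here means a stronger inhibitor, a higher number a weaker inhibitor), compound 1 gives 1700 nM, and compound 2 gives 3900 nM. The step of a 2.3-fold higher number from compound 1 to compound 2 (0.36 log units; beyond the scatter) is the only one measured so far, and compound 2 stands at the higher of the two numbers, the weaker inhibitor. Compound 3 `CNc1cccc2c1cnn2-c1ccc(NC(=O)Nc2ccc(Cl)c(C(F)(F)F)c2)cc1` carries the change (methylamino in place of methyl on an aromatic carbon). Going by the values given here, no measured step involves a methylamino group, so the only pointer is the modest size of a 2.3-fold higher number from compound 1 to compound 2 (0.36 log units; beyond the scatter), which shows that a change at this carbon has moved this assay by a small amount. Nothing here supports a direction for the new step, and the estimated step of a 1.3-fold lower number from compound 2 to compound 3 (0.11 log units; within the scatter) is therefore expected to be small. Compound 3 is expected to give 3000 nM, within 1200 nM to 8000 nM, in this assay.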

Compound 3, half-maximal inhibitory concentration: 6300 nM
Compound 3: middle estimate off by 2.1-fold (0.32 log units), on the low side; the range from low to high includes it.
By their numbers in this assay, from the lowest: compound 1; then compounds 2 and 3 (each within the scatter of the next).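

In this assay, methylamino in place of methyl gives a 1.6-fold higher number from compound 2 to compound 3 (0.21 log units; within the scatter), so the two groups cannot be told apart at this aromatic carbon, even though methylamino brings one hydrogen-bond donor and one hydrogen-bond acceptor that methyl lacks. Methylamino in place of bromo gives a 3.7-fold higher number from compound 1 to compound 3 (0.57 log units; beyond the scatter), which leaves compound 1, with bromo, as the strongest inhibitor of the three, with both of its steps beyond the scatter. No available evidence bears on why these numbers fall as they do.

The compounds shown leave open how a primary amine, a methoxy group or a chlorine at this carbon would read in this assay. They also leave open whether bromo would keep its edge over methylamino with a change elsewhere on the shared core.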